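From 3-chlorobenzyl to 3-chlorophenyl on the amino nitrogen

A few compounds are considered here, and "the series" means these few. Any claim that something is new, unique, unknown or untested is made for them only; others in the source may bear on it.

In a functional assay on MCF7 cells (Homo sapiens) for inhibition, read by fluorescence, with a stated time of 72 h (on this read-out higher numbers stand for weaker inhibition of growth and lower numbers for stronger inhibition of growth), compound 1 (`CCCCn1cnc2c(NCc3cccc(Cl)c3)nc(N[C@H]3CC[C@H](N)CC3)nc21`) reads 2200 nM and compound 2 (`CC(C)CCn1cnc2c(NCc3cccc(Cl)c3)nc(N[C@H]3CC[C@H](N)CC3)nc21`) reads 4700 nM while compound 3 (`N[C@H]1CC[C@H](Nc2nc(Nc3ccc(O)cc3)c3ncn(C4CCCCC4)c3n2)CC1`) reads 9600 nM on the same scale. Compound 2 therefore holds the second highest number of the three. Compound 4 (`CC(C)CCn1cnc2c(Nc3cccc(Cl)c3)nc(N[C@H]3CC[C@H](N)CC3)nc21`) has 3-chlorophenyl in place of 3-chlorobenzyl on a nitrogen on an aromatic ring and otherwise matches compound 2. Among the compounds with values here, no measured step touches that place. Within the data shown here, the only single-place step available, a 2.1-fold higher number from compound 1 to compound 2 (0.33 log units; beyond the scatter) on the saturated chain, is modest and lies elsewhere in the molecule. Compound 3 also carries an aromatic ring directly on that nitrogen, but it differs from compound 2 in other places too, so compound 3 at 9600 nM cannot be read as this change alone. With so little direct evidence, the estimated change in this assay is a 1.3-fold lower number from compound 2 to compound 4 (0.13 log units; within the scatter) and no step beyond the scatter is expected. For compound 4 the estimated value is 3500 nM with an expected range from 900 nM to 12000 nM for the measurement.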

Compound 4, concentration for 50% growth inhibition: 2100 nM
Compound 4: the middle estimate sits 1.7-fold (0.22 log units) above what was measured; low and high end bracket the measured number.
By their numbers in this assay, from the lowest: compounds 4 and 1 (each within the scatter of the next); then compound 2; then compound 3.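

Within the data shown here, this is the first measured step at this position: in this assay there is a 2.2-fold lower number from compound 2 to compound 4 (0.35 log units; beyond the scatter), with 3-chlorophenyl in place of 3-chlorobenzyl on a nitrogen on an aromatic ring. The step is modest but beyond the scatter, so this nitrogen substituent does affect growth inhibition, and the smaller group of 7 heavy atoms, against 8, gives the stronger inhibition of growth here. Nothing available explains this change.

The compounds shown leave open whether the same change would hold with the chain of compound 1 or with the cyclohexyl group of compound 3 at the other site. They also leave open how a longer link such as 3-chlorophenethyl, or a nitrile or methoxy group in place of the chlorine, would read at this position.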